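This account rests on a few compounds, and the source may have more. Where it says the series, first, only, none or still open, it means among the compounds named here.

Measured so far:
- compound 1, `CN1CCCN(CCn2ccc3ccc(F)cc32)CC1`, 288 nM
- compound 2, `CN1CCCN(CCn2ccc3ccc(OCc4ccccc4)cc32)CC1`, 182 nM
- compound 3, `C#Cc1ccc2ccn(CCN3CCCN(C)CC3)c2c1`, 140 nM

All three were tested in an assay on HEK293 cells for binding affinity to 5-hydroxytryptamine receptor 7 (Homo sapiens), read by radioligand binding (on this read-out lower numbers stand for stronger inhibition and higher numbers for weaker inhibition), and they share one core, differing only in the group on one aromatic carbon. Compound 3 gives the lowest of the three numbers in this assay. Its nearest neighbour is compound 2; that gap, a 1.3-fold lower number from compound 2 to compound 3 (0.11 log units; within the scatter), lies within the scatter, so the two cannot be told apart. Against compound 1 the gap is a 2.1-fold lower number from compound 1 to compound 3 (0.31 log units; beyond the scatter), a modest step beyond the scatter. The third step, a 1.6-fold lower number from compound 1 to compound 2 (0.20 log units; within the scatter), is again within the scatter.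

Compound 4, `Cc1ccc2ccn(CCN3CCCN(C)CC3)c2c1`, has not been tested yet. It carries methyl in place of ethynyl on an aromatic carbon. Going by the values given here, no measured step involves a methyl group, so nothing speaks directly to this change. What the three measured compounds do show is that three quite different groups at this carbon — fluoro, benzyloxy, ethynyl — all land within a narrow band in this assay. On that basis compound 4 is expected to stay inside the same band, with the change a 1.6-fold higher number from compound 3 to compound 4 (0.20 log units; within the scatter) likely to be no more than modest and probably upward. The estimate for compound 4 is 220 nM, with a plausible range from 100 nM to 500 nM.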

Compound 4, inhibition constant: 125 nM
The estimate for compound 4 lay 1.8-fold (0.25 log units) above the measured number; measured number inside the range.
By their numbers in this assay, from the lowest: compounds 4, 3, 2 and 1 (each within the scatter of the next, the first and the last beyond it).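

Replacing the ethynyl group with methyl removes a triple bond and one carbon from this position, yet this assay gives a 1.1-fold lower number from compound 3 to compound 4 (0.05 log units; within the scatter), so compound 3 and compound 4 cannot be told apart and the triple bond is not needed to keep a number of this size. The methyl group also cannot be separated from the much larger benzyloxy group, with a 1.5-fold lower number from compound 2 to compound 4 (0.16 log units; within the scatter), but it does stand apart from fluoro, with a 2.3-fold lower number from compound 1 to compound 4 (0.36 log units; beyond the scatter), a modest step beyond the scatter that matches the one seen for ethynyl. Compound 2 goes against any simple split. It cannot be told apart from compound 1 or from the two carbon-substituted compounds. No available evidence bears on the reason for these results.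

All four groups shown carry no charge and no hydrogen-bond donor, so it remains open whether an amine or a carboxylic acid on this aromatic carbon would stay in the same narrow band. The same question stands for a longer chain, and for the unsubstituted core with only hydrogen at this carbon.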